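Replacing a fluorophenyl with a dihydroxyphenyl hydrazone

This account rests on a few compounds, and the source may have more. Where it says the series, first, only, none or still open, it means among the compounds named here.

Of the compounds shown here, three built on one shared core have been tested in a functional assay on HCT-116 cells (Homo sapiens) for inhibition, read by MTT assay, with a stated time of 48 h; a lower number here means a stronger inhibitor, a higher number a weaker inhibitor. Compound 1 `Fc1cccc(F)c1CSc1nnc(-c2ccncc2)n1-c1ccccc1` gives 22100 nM. Compound 2 `O=C(CSc1nnc(-c2ccncc2)n1-c1ccccc1)N/N=C/c1ccc(Br)cc1` gives 4500 nM, and compound 3 `O=C(CSc1nnc(-c2ccncc2)n1-c1ccccc1)N/N=C/c1ccc(F)cc1` gives 7040 nM. Compound 3 thus stands second highest of the three numbers; its nearest neighbour is compound 2, within the scatter, and its furthest is compound 1, beyond the scatter. Compound 4 `O=C(CSc1nnc(-c2ccncc2)n1-c1ccccc1)N/N=C/c1ccc(O)c(O)c1` differs from compound 3 by 3,4-dihydroxyphenyl in place of 4-fluorophenyl on a carbon with a double bond to nitrogen. Within the data shown here, the only measured step at this ring, a 1.6-fold higher number from compound 2 to compound 3 (0.19 log units; within the scatter), stayed within the scatter, and no measured step exchanges a halogen for hydroxyl groups. The step is therefore expected to be a 1.0-fold lower number from compound 3 to compound 4 (0.00 log units; within the scatter), nothing beyond the scatter. Compound 4 is estimated at 7000 nM, within 2500 nM to 20000 nM.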

Compound 4, half-maximal inhibitory concentration: 14700 nM
Beside the measured number, compound 4's estimate is 2.1-fold (0.32 log units) below it, within the range that was stated.
By their numbers in this assay, from the lowest: compounds 2 and 3 (each within the scatter of the next); then compounds 4 and 1 (each within the scatter of the next).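

At this ring a halogen exchange stayed within the scatter, but 3,4-dihydroxyphenyl on the carbon with a double bond to nitrogen gives a 2.1-fold higher number from compound 3 to compound 4 (0.32 log units; beyond the scatter) and a 3.3-fold higher number from compound 2 to compound 4 (0.51 log units; beyond the scatter) and so moves beyond it, if only modestly. The position therefore does respond to the group it carries, and here the response is toward weaker inhibition. No evidence at hand says why.

The compounds shown leave open whether a single hydroxyl would give the same shift. They also leave open how a methoxy group, an amine or a carboxylic acid on this ring would read.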